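Swapping a fluoro group for amino in a cytotoxicity read-out

The source may report more compounds than this note shows. Statements on the series, on what has been measured and on what is new or still open speak of the compounds shown alone.

Measured so far in a functional assay on V79 cells (Cricetulus griseus) for cytotoxicity, read by colony formation; on this read-out higher numbers stand for weaker inhibition and lower numbers for stronger inhibition
compound 1 `Nc1c(F)c(N2CCC(N)C2)cc2c1c(=O)c(C(=O)O)cn2C1CC1` gives 54 ug/mL
compound 2 `NC1CCN(c2c(F)c(F)c3c(=O)c(C(=O)O)cn(C4CC4)c3c2F)C1` gives 100 ug/mL

These two values lie within the usual scatter of each other, so on these numbers compound 2 cannot be told apart from compound 1. Compound 3 `Nc1c(F)c(N2CCC(N)C2)c(F)c2c1c(=O)c(C(=O)O)cn2C1CC1` has not been measured yet. It differs from compound 2 at one place, with amino in place of fluoro on an aromatic carbon.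

For the measured compounds named here, no two measured compounds differ at only one place, so no measured step shows directly what this swap does. The nearest hint is compound 1 at 54 ug/mL, which also carries an amino group in that place but lacks a fluoro group that compound 3 keeps. In this assay a modest move towards a lower number, meaning stronger inhibition, is therefore expected. The expected step is a 2.5-fold lower number from compound 2 to compound 3 (0.40 log units; beyond the scatter) and could still fall within the scatter. For compound 3 the estimated value is 40 ug/mL, with a range from 13 ug/mL to 110 ug/mL.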

Compound 3, half-maximal inhibitory concentration: 15 ug/mL
Compound 3: middle estimate off by 2.7-fold (0.43 log units), on the high side; the range from low to high includes it.
By their numbers in this assay, from the lowest: compound 3; then compounds 1 and 2 (each within the scatter of the next).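

In this assay, the change from fluoro to amino on this aromatic carbon, which sits ortho to a fluoro group and meta to the 3-aminopyrrolidin-1-yl group, now has a direct measure: it gives a 6.7-fold lower number from compound 2 to compound 3 (0.82 log units; beyond the scatter) and so goes with stronger inhibition of the cells. The fluoro group para to the amino also counts, since fluoro in place of hydrogen on an aromatic carbon gives a 3.6-fold lower number from compound 1 to compound 3 (0.56 log units; beyond the scatter) and this step, too, lies beyond the scatter, so with amino in place both changes move the number the same way. Nothing measured here explains either step.

On these data alone, each change is read from a single pair of compounds, so it remains open whether either step would keep its direction and size on a different core or with a different group in place of the 3-aminopyrrolidin-1-yl group. As far as these compounds go, it is also open how other small groups on the carbon that carries the amino, such as hydroxyl, methoxy or methylamino, would compare with amino and fluoro on this read-out.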